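A few compounds are considered here, and "the series" means these few. Any claim that something is new, unique, unknown or untested is made for them only; others in the source may bear on it.

Compound 2 `Nc1nc2cc(-c3nn(CCCCCC(=O)NO)c4ncnc(N)c34)ccc2o1` carries the highest of the two numbers measured in a functional assay on CNE-2 cells (Homo sapiens) for inhibition, read by MTT assay, with a stated time of 72 h; on this read-out lower numbers stand for stronger inhibition and higher numbers for weaker inhibition: compound 2 gives 37600 nM. Its nearest neighbour, compound 3 `Nc1ncnc2c1c(-c1cnc3[nH]ccc3c1)nn2CCCCCCCCC(=O)NO`, gives 2270 nM in this assay. Compound 1 `Nc1ncnc2c1c(-c1cnc3[nH]ccc3c1)nn2CCCC(=O)NO` gives in this assay only a limit of the assay, > 150000 nM. The step to compound 4 `Nc1nc2cc(-c3nn(CCC(=O)NO)c4ncnc(N)c34)ccc2o1` shortens the chain that ends in the hydroxycarbamoyl group: hydroxycarbamoyl in place of 3-(hydroxycarbamoyl)propyl on a saturated chain carbon, two bonds along the chain from an aromatic nitrogen. Among the compounds with values here, one measured step bears on this, the lengthening of the same kind of chain, which gave an at least 66-fold lower number from compound 1 to compound 3 (1.82 log units; beyond the scatter). Going by these compounds, that step started at a limit, (the limit of > 150000 nM in this assay, at which 1 of the 3 values shown sits), so its true size is unknown but at least large. Going the other way, shortening the chain of compound 2, is therefore expected to raise the number, by about a 4.8-fold higher number from compound 2 to compound 4 (0.68 log units; beyond the scatter). Compound 4 is estimated at 180000 nM in this assay, within a range from 60000 nM to 600000 nM, and this assay may well report only a limit for compound 4.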

Compound 4, half-maximal inhibitory concentration: > 150000 nM
Compound 4 gave a limit, no number (the forecaster's own chance of this, stated with the estimate: 60%); the middle value does not contradict the limit.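

In this assay compound 4 gives > 150000 nM and that is a limit of the assay, not a number. Shortening the chain gives an at least 3.9-fold higher number from compound 2 to compound 4 (0.60 log units; beyond the scatter) and so shows that chain length at this position also matters with a second aromatic group on the core, since the earlier chain step came only from the pair sharing the other group, and in both pairs the shorter chain gives the higher number. This step is only a minimum, because the value of compound 4 sits at the assay's limit: the limit of > 150000 nM in this assay, at which 2 of the 4 values shown sit.

Going by these compounds, how far the number would drop with a longer chain on the core of compound 2 stays open. Also open, on these data alone, is what a carboxylic acid would do in place of the hydroxycarbamoyl group that ends the chain.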